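Chlorine Placement on the Aryl Ring and Cytotoxicity

The source may hold more compounds than are shown below. What is called first, only, known or untested is meant among the compounds shown, and "the series" means these compounds.

Measured in a toxicity assay on J774.A1 cells (Mus musculus) for cytotoxicity, read by SYBR Green assay, with a stated time of 1 h; a lower number here means that less compound is needed, a higher number that more compound is needed for the effect:
Compound 1, `CN(C)c1ccc2cc(-c3ccccc3Cl)c(N)nc2c1`: 2400 nM
Compound 2, `CN(C)c1ccc2cc(-c3ccc(Cl)cc3)c(N)nc2c1`: 2900 nM
Compound 3, `CN(C)c1ccc2cc(-c3cccc(Cl)c3Cl)c(N)nc2c1`: 4900 nM

Compounds 1 and 2 share the same atoms joined differently: 4-chlorophenyl in place of 2-chlorophenyl on an aromatic carbon. This gives a 1.2-fold higher number from compound 1 to compound 2 (0.08 log units; within the scatter), so the two read-outs cannot be told apart. Compound 3 adds a second chlorine to compound 1: chloro in place of hydrogen on an aromatic carbon. That change gives a 2.0-fold higher number from compound 1 to compound 3 (0.31 log units; beyond the scatter), a modest shift toward needing more compound.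

Compound 4, `CN(C)c1ccc2cc(-c3ccc(Cl)c(Cl)c3)c(N)nc2c1`, has not yet been measured in this assay. Within the data shown here, it differs from compound 2 by chloro in place of hydrogen on an aromatic carbon, which is the same change as the one from compound 1 to compound 3; the surroundings of the new chloro group are described in the same words in both cases.

The expectation for compound 4 therefore rests on one measured example. Among the measured compounds shown here, compound 4 is estimated to show a 1.9-fold higher number from compound 2 to compound 4 (0.28 log units; within the scatter), because a 2.0-fold higher number from compound 1 to compound 3 (0.31 log units; beyond the scatter) is the only measured guide available. On that basis compound 4 is expected to give about 5500 nM in this assay, plausibly between 3000 nM and 11000 nM.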

Compound 4, half-maximal effective concentration: 3200 nM
The estimate for compound 4 lay 1.7-fold (0.24 log units) above the measured number; the range from low to high includes it.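

In this assay, the added chloro group gives a 1.1-fold higher number from compound 2 to compound 4 (0.04 log units; within the scatter), so on this core the change cannot be told apart from no change at all. Set beside the earlier example, the two steps do not differ by more than repeated measurements would allow: the same change on two cores in this assay, a 2.0-fold higher number (0.31 log units; beyond the scatter) from compound 1 to compound 3 and a 1.1-fold higher number (0.04 log units; within the scatter) from compound 2 to compound 4, 1.9-fold (0.27 log units) apart, within the scatter of two such steps. This shows that no difference between the two cores can be resolved for this change, but it does not show that the step has a fixed size, as one step lies beyond the scatter and the other within it, and two pairs cannot settle whether the core matters.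

The compounds shown carry only chloro groups on the aromatic ring, so it remains open whether the same comparison would hold for another group in that place, such as fluoro, methoxy or a carboxylic acid. From the compounds shown here alone, it also remains open whether the step would hold on a core carrying an amine with a longer chain.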